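Trimethoxyphenyl Ketone Variant of a Thymidine-Linked Benzophenone

The compounds below may be only part of what the source reports. "The series", "measured", "known", "first", "only" and "open" are said of these compounds alone.

Among the measured compounds shown here, compound 2 `COc1ccc(C(=O)c2cccc(Cl)c2)cc1OC(=O)CCC(=O)OC[C@@H]1C=C[C@H](n2cc(C)c(=O)[nH]c2=O)O1` has the highest of the two numbers so far measured in a functional assay on HepG2 cells (Homo sapiens) for antiproliferative activity, read by MTT assay, with a stated time of 48 h (a lower number here means a stronger inhibitor, a higher number a weaker inhibitor), where compound 2 gives 11100 nM; the nearest is compound 1 `COc1cccc(C(=O)c2ccc(OC)c(OC(=O)CCC(=O)OC[C@@H]3C=C[C@H](n4cc(C)c(=O)[nH]c4=O)O3)c2)c1`, which in this assay gives 3150 nM. Compound 3 `COc1cc(OC)c(C(=O)c2ccc(OC)c(OC(=O)CCC(=O)OC[C@@H]3C=C[C@H](n4cc(C)c(=O)[nH]c4=O)O3)c2)cc1OC` has not yet been measured; it differs from compound 2 in one place (2,4,5-trimethoxyphenyl in place of 3-chlorophenyl on a carbonyl carbon). For the measured compounds named here, the one measured step that bears on this change is the move between the two aryl groups on the carbonyl carbon, a 3.5-fold higher number from compound 1 to compound 2 (0.55 log units; beyond the scatter), where chloro replaced methoxy and the number rose. Compound 3 restores methoxy groups on that ring, so a step back toward or beyond compound 1 is expected, a 3.2-fold lower number from compound 2 to compound 3 (0.50 log units; beyond the scatter). In this assay compound 3 is estimated at 3500 nM, with a likely range from 1000 nM to 12000 nM.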

Compound 3, half-maximal inhibitory concentration: 6850 nM
Compound 3: the middle estimate sits 2.0-fold (0.29 log units) below what was measured, within the range that was stated.
By their numbers in this assay, from the lowest: compound 1; then compounds 3 and 2 (each within the scatter of the next).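

In this assay, the 2,4,5-trimethoxyphenyl group on the carbonyl carbon gives a 1.6-fold lower number from compound 2 to compound 3 (0.21 log units; within the scatter), so this larger ring with its three acceptors cannot be told apart from 3-chlorophenyl at this place. Against 3-methoxyphenyl, the same change gives a 2.2-fold higher number from compound 1 to compound 3 (0.34 log units; beyond the scatter), which shows that methoxy on this ring does not by itself bring the number back down: of these three compounds, only compound 1, with its single methoxy group, stands apart. Nothing available here bears on the reason for this. On these data alone, whether an unsubstituted phenyl, a 3-hydroxyphenyl or a 3-aminophenyl group on the same carbonyl carbon would match compound 1 remains open. So does whether a ring with two methoxy groups would fall with compound 1 or with compound 3.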